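Propylamino for cyano: a step beyond the known numbers

The compounds below may be only part of what the source reports. "The series", "measured", "known", "first", "only" and "open" are said of these compounds alone.

Within the data shown here, compound 2 `CC(C)(C)c1ccc(NC(=O)c2ccc(-c3ncccc3C#N)cc2)cc1` gives 13 nM in a functional assay for antagonist activity at transient receptor potential cation channel subfamily V member 1 (Rattus norvegicus) (a higher number here means a weaker inhibitor, a lower number a stronger inhibitor), the highest of the two numbers known here; its nearest neighbour is compound 1 `Cc1cccnc1-c1ccc(C(=O)Nc2ccc(C(C)(C)C)cc2)cc1`, which gives 9 nM. Among the measured compounds shown here, the only measured step, a 1.4-fold higher number from compound 1 to compound 2 (0.16 log units; within the scatter), lay within the scatter. Compound 3 `CCCNc1cccnc1-c1ccc(C(=O)Nc2ccc(C(C)(C)C)cc2)cc1` differs from compound 2 by propylamino in place of cyano on an aromatic carbon. For the measured compounds named here, no measured step brings in a propylamino group, so the methyl-to-cyano step offers only weak guidance. The step expected here, a 1.5-fold higher number from compound 2 to compound 3 (0.19 log units; within the scatter), is small and of uncertain direction. Compound 3 is estimated at 20 nM, with a range from 5 nM to 80 nM.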

Compound 3, half-maximal inhibitory concentration: 37 nM
For compound 3 the middle estimate is 1.9-fold (0.27 log units) below the measured one; the range from low to high includes it.
By their numbers in this assay, from the lowest: compounds 1 and 2 (each within the scatter of the next); then compound 3.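

At this position, ortho to a large group and two atoms from the ring nitrogen, the earlier swap of methyl for cyano left the number within the scatter, but propylamino moves it beyond the scatter in this assay, with a 2.8-fold higher number from compound 2 to compound 3 (0.45 log units; beyond the scatter) and a 4.1-fold higher number from compound 1 to compound 3 (0.61 log units; beyond the scatter). The position is therefore not indifferent to its substituent, although both steps remain modest. Nothing available explains this rise.

From the compounds shown here alone, it remains open whether the rise follows the length of the chain or the amine hydrogen. An unsubstituted amine, methylamino and dimethylamino at this place would separate the two.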